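A few compounds are considered here, and "the series" means these few. Any claim that something is new, unique, unknown or untested is made for them only; others in the source may bear on it.

Of the compounds shown here, two have been tested in an ADME assay on U-937 cells (Homo sapiens) for cytotoxicity, read by MTT assay, with a stated time of 24 h, tested at 20 uM; a lower number here means a stronger effect, a higher number a weaker effect of the compound at the concentration tested. Compound 1 `CCCCCc1cc(O)cc(O)c1Oc1cc2c(cc1OC)C(O)(CCCC)OC2=O` gives 124% in this assay. Compound 2 `CCCCCc1c(Oc2cc3c(cc2OC)C(CCCC)(OC)OC3=O)c(O)cc(O)c1C(=O)O` gives 131% in this assay, the larger of the two numbers, with compound 1 within the usual scatter of it. Compound 3 `CCCCCc1cc(O)cc(O)c1Oc1cc2c(cc1OC)C(CCCC)(OC)OC2=O` has not been measured; against compound 2 it shows (hydrogen in place of carboxy on an aromatic carbon). Among the compounds with values here, no step between measured compounds bears on this change, so no shift beyond the scatter is expected in this assay. For compound 3 the estimated value is 125%, with a range from 105% to 145%. This corresponds to an expected step of a number 6 percentage points lower from compound 2 to compound 3 (within the scatter).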

Compound 3, a percentage reported as activity, at one concentration (the size of the read-out at that concentration, not a potency): 96%
Beside the measured number, compound 3's estimate is 29 percentage points above it; measured number below the stated range.
By their numbers in this assay, from the lowest: compound 3; then compounds 1 and 2 (each within the scatter of the next).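

In this assay, replacing the carboxy group on the aromatic carbon with hydrogen gives a number 35 percentage points lower from compound 2 to compound 3 (beyond the scatter), so this position affects the read-out when the methyl on the oxygen is present. Methyl in place of hydrogen on the oxygen on a saturated carbon gives a number 28 percentage points lower from compound 1 to compound 3 (beyond the scatter), showing that a second site also moves the read-out. Nothing available accounts for either step.

The compounds shown leave open whether an amide or a methyl ester at the carboxy position would behave like the carboxy group or like hydrogen. They also leave open how an ethyl group on that oxygen would compare with methyl.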